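The source may hold more compounds than are shown below. What is called first, only, known or untested is meant among the compounds shown, and "the series" means these compounds.

Measured so far:
- compound 1 `O=c1c2ccccc2c(-c2cccnc2)nn1CC1CCCCC1`: 98%
- compound 2 `O=c1c2ccccc2c(-c2cccnc2)nn1CCCCSc1ncccn1`: 96%

In an assay on isolated protein (Oryctolagus cuniculus) with Thromboxane-A synthase (Homo sapiens) as the target, tested at 1 uM (a higher number here means more inhibition at the concentration tested (going by the name of the read-out), a lower number less inhibition), compound 1 gives 98%, the higher of the two numbers recorded, while compound 2 gives 96%, a reading within the usual scatter of compound 1, so the two cannot be ranked against each other. Compound 3 `O=C(O)Cn1nc(-c2cccnc2)c2ccccc2c1=O` has not been measured. It differs from compound 1 in one place: carboxy in place of cyclohexyl on a saturated chain carbon bound to an aromatic nitrogen. Among the measured compounds shown here, no measured pair shows this change, so the expected size of the step rests on judgment. Compound 3 is expected to show a drop beyond the scatter, a number 28 percentage points lower from compound 1 to compound 3 (beyond the scatter), giving an estimated 70% in this assay, between 35% and 95%.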

Compound 3, a percentage reported as inhibition, at one concentration (the size of the read-out at that concentration, not a potency): 13%
For compound 3 the middle estimate is 57 percentage points above the measured one; the measured number lies below the stated range.
By their numbers in this assay, from the lowest: compound 3; then compounds 2 and 1 (each within the scatter of the next).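

In this assay, putting carboxy in place of cyclohexyl on a saturated chain carbon bound to an aromatic nitrogen gives a number 85 percentage points lower from compound 1 to compound 3 (beyond the scatter) in this single change. Among the compounds shown here, this is the first sign that the group at this position can decide how much inhibition remains at the concentration tested. No measurement available here gives a reason for the loss. From the compounds shown here alone, it remains open whether the loss comes from adding the carboxy or from removing the cyclohexyl. A methyl ester or an amine in the same place could help separate these two possibilities.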